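Swapping the Pendant Aryl Ring: A Forecast for Compound 3

The source may hold more compounds than are shown below. What is called first, only, known or untested is meant among the compounds shown, and "the series" means these compounds.

Compound 1, `Cc1nc2c3ccccc3ccc2c2nc3c(ccc4ccccc43)c(-c3cccnc3)c12`, gives 63.6 ug/mL in a functional assay, read by spectrophotometry, with a stated time of 15 min; on this read-out higher numbers stand for weaker inhibition and lower numbers for stronger inhibition.
Compound 2, `Cc1nc2c3ccccc3ccc2c2nc3c(ccc4ccccc43)c(-c3cccc4ccccc34)c12`, gives 64.3 ug/mL in this assay.

Compound 1 and compound 2 share one core and differ only in the ring hung from it. Compound 2 stands at essentially the same number as compound 1: the step of a 1.0-fold higher number from compound 1 to compound 2 (0.00 log units; within the scatter) lies within the scatter, so the two cannot be told apart. Compound 3, `Cc1nc2c3ccccc3ccc2c2nc3c(ccc4ccccc43)c(-c3cc([N+](=O)[O-])ccc3N)c12`, is not yet measured. Relative to compound 2 it carries 2-amino-5-nitrophenyl in place of naphthalen-1-yl on an aromatic carbon. Within the data shown here, the one measured step, a 1.0-fold higher number from compound 1 to compound 2 (0.00 log units; within the scatter), also swapped one aromatic ring for another on this same carbon and left the number unchanged, which is the only guide available. The incoming group brings a hydrogen-bond donor and acceptors that neither earlier ring had, so the forecast is less certain. In this assay the expected step is a 1.0-fold lower number from compound 2 to compound 3 (0.02 log units; within the scatter), none beyond the scatter. Compound 3 is therefore estimated at 62 ug/mL, within a range from 28 ug/mL to 135 ug/mL.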

Compound 3, half-maximal inhibitory concentration: 43.3 ug/mL
For compound 3 the middle estimate is 1.4-fold (0.16 log units) above the measured one, within the range that was stated.
By their numbers in this assay, from the lowest: compounds 3, 1 and 2 (each within the scatter of the next).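

At the aromatic carbon opposite the ring nitrogen, 2-amino-5-nitrophenyl replaces naphthalen-1-yl with a 1.5-fold lower number from compound 2 to compound 3 (0.17 log units; within the scatter) in this assay and replaces pyridin-3-yl with a 1.5-fold lower number from compound 1 to compound 3 (0.17 log units; within the scatter) on the same read-out. Compound 3 thus brings an amino group and a nitro group to this carbon, yet it cannot be told apart from compound 1 or compound 2, so the three aromatic groups shown read alike here. No measurement offered here explains this result.

The compounds shown leave open whether the amino group or the nitro group matters on its own, which a phenyl ring carrying only one of them could test. They also leave open how this carbon responds to a group that is not an aromatic ring, such as a carboxylic acid or a butyl chain.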